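Dropping the isopropylcarbonyl from compound 1

The source may report more compounds than this note shows. Statements on the series, on what has been measured and on what is new or still open speak of the compounds shown alone.

In an ADME assay on MT4 cells (Homo sapiens) for cytotoxicity, read by a luciferase reporter, with a stated time of 3 days (a lower number here means that less compound is tolerated, a higher number that more compound is tolerated), compound 1 `CC(C)C(=O)O[C@@H]1[C@@H](CO)O[C@@H](n2ccc(N)nc2=O)C12CC2` gives > 98400 nM as its reading, which is a limit and not a number. Compound 2 `CC(C)C(=O)OC[C@H]1O[C@@H](n2ccc(N)nc2=O)C2(CC2)[C@@H]1OC(=O)C(C)C` gives > 98400 nM as its reading, again a limit. Within the data shown here, the series so far shows the limit of > 98400 nM in this assay, at which 2 of the 2 values shown sit, and nothing lower. The change to compound 3 `Nc1ccn([C@@H]2O[C@H](CO)[C@@H](O)C23CC3)c(=O)n1` is hydrogen in place of isopropylcarbonyl on an oxygen on a saturated carbon and reads as (isopropylcarbonyl)oxy to hydroxy. Among the measured compounds shown here, the only measured step of this kind, taken in the opposite sense, leads to compound 2 as a step that the two limits leave unreadable from compound 1 to compound 2 and gives no size to carry over. On that step alone, no change beyond the scatter is expected in this assay in either direction. The estimated move is a number no higher from compound 1 to compound 3 (the limit leaves the size open) on this reading. The expected value for compound 3 is 98400 nM with an estimated range of 45000 nM to 120000 nM and a report as a limit is likely.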

Compound 3, half-maximal cytotoxic concentration: > 98400 nM
Compound 3 ended at the assay's limit; the forecaster's own chance of this, stated with the estimate: 85%; the middle value lies on the limit itself.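

No step between compound 1 and compound 3 can be read in this assay, because both readings are limits and not numbers: the limit of > 98400 nM in this assay, at which 3 of the 3 values shown sit.

Going by these compounds, whether compound 1, compound 2 and compound 3 differ at all in this assay stays open, and so does the size of any effect of removing the isopropylcarbonyl.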